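Chloro Next to the Ring Nitrogen: Expected Potency Shift

A few compounds are considered here, and "the series" means these few. Any claim that something is new, unique, unknown or untested is made for them only; others in the source may bear on it.

Measured in an in vitro functional assay on 1321-N1 cells for agonist activity at Free fatty acid receptor 1 (Homo sapiens), read by fluorescence, spectrophotometry and calcium flux; a higher number here means that more compound is needed for the effect, a lower number that less compound is needed:
compound 1 `Cc1c(C#Cc2ccc(CCC(=O)O)cc2)ccnc1Cl` gives 135 nM
compound 2 `Cc1c(C#Cc2ccc(CCC(=O)O)cc2)cc(Cl)nc1Cl` gives 43.7 nM
compound 3 `O=C(O)CCc1ccc(C#Cc2cccnc2)cc1` gives 6030 nM

Compound 2 differs from compound 1 by chloro in place of hydrogen on an aromatic carbon, and this gave a 3.1-fold lower number from compound 1 to compound 2 (0.49 log units; beyond the scatter). Compound 3 stands highest of the three; the difference between its core and the core of compound 1 is not broken down here. Compound 4 `O=C(O)CCc1ccc(C#Cc2cccnc2Cl)cc1` is not yet measured; it differs from compound 3 by chloro in place of hydrogen on an aromatic carbon. This is the same kind of change as that from compound 1 to compound 2, but the place differs: in compound 4 the chloro is ortho to a large group, whereas in compound 2 it is meta to a chloro group, meta to a large group and para to a methyl group. Resting on compound 1 and compound 2 with a 3.1-fold lower number from compound 1 to compound 2 (0.49 log units; beyond the scatter), compound 4 is expected to show a 3.0-fold lower number from compound 3 to compound 4 (0.48 log units; beyond the scatter) in this assay. The place differs, and the doubt is wider for that. The estimate for compound 4 is 2000 nM, between 500 nM and 7000 nM.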

Compound 4, half-maximal effective concentration: 603 nM
Compound 4: middle estimate off by 3.3-fold (0.52 log units), on the high side; low and high end bracket the measured number.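

In this assay the change gave a 10-fold lower number from compound 3 to compound 4 (1.00 log units; beyond the scatter) on the second core, so the direction of the step carried over from one core to the other. Its size did not carry over, and the two steps stand apart: the same change on two cores in this assay, a 3.1-fold lower number (0.49 log units; beyond the scatter) from compound 1 to compound 2 and a 10-fold lower number (1.00 log units; beyond the scatter) from compound 3 to compound 4, 3.2-fold (0.51 log units) apart, beyond the scatter of two such steps. The two pairs differ both in the core and in the place of the chloro, so they do not show which of these sets the size of the step, and two pairs make no rule for the series.

The compounds shown leave open whether bromo or methoxy in the same place, next to the ring nitrogen, would lower the number as chloro does. They also leave open how a chloro on the core of compound 3 would act in any other place.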